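The source may hold more compounds than are shown below. What is called first, only, known or untested is meant among the compounds shown, and "the series" means these compounds.

Measured compounds:
compound 1, `CC(C)Sc1nc(C(C)c2c(F)cccc2Cl)cc(=O)[nH]1`, an ADME assay on MT4 cells (Homo sapiens) for activation, read by MTT assay; on this read-out lower numbers stand for higher toxicity in this test and higher numbers for lower toxicity in this test: > 75000 nM.
compound 2, `CCCSc1nc(C(C)c2c(F)cccc2Cl)cc(=O)[nH]1`, this assay: > 75000 nM.
compound 3, `Cc1c(C(C)c2c(F)cccc2Cl)nc(SC(C)C)[nH]c1=O`, this assay: > 15000 nM.

The value of compound 1 in this assay is a limit of the assay, not a number. The value of compound 2 in this assay is likewise only a limit. The value of compound 3 in this assay is again a limit, and it sits at the limit of > 15000 nM in this assay, at which 1 of the 3 values shown sits, whereas the other two sit at the limit of > 75000 nM in this assay, at which 2 of the 3 values shown sit.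

The change from compound 1 to compound 2 is propyl in place of isopropyl on a sulfur. In this assay it gives a step that the two limits leave unreadable from compound 1 to compound 2. The change from compound 1 to compound 3 is methyl in place of hydrogen on an aromatic carbon, and in this assay it gives a step that the two limits leave unreadable from compound 1 to compound 3.

Compound 4, `CCCSc1nc(C(C)c2c(F)cccc2Cl)c(C)c(=O)[nH]1`, has not been measured in this assay. It differs from compound 3 by propyl in place of isopropyl on a sulfur. This is the same change as that from compound 1 to compound 2, the place lines agreeing word for word; the cores of the two pairs differ by methyl in place of hydrogen on an aromatic carbon.

In this assay compound 4 is expected to show a step that the limit leaves unreadable from compound 3 to compound 4, that is, no readable difference from compound 3, resting on the outcome of the same change in compound 2, which gave > 75000 nM. The estimate for compound 4 in this assay is 100000 nM, expected to lie between 20000 nM and 400000 nM, most likely reported as a limit.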

Compound 4, half-maximal cytotoxic concentration: > 1500 nM
Compound 4: only a limit was reported; the forecaster's own chance of this, stated with the estimate: 85%; the middle value is on the limit's open side.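

Compound 4 gives > 1500 nM in this assay as a limit of the assay, not a number. With limits on both sides, neither the change from compound 3 to compound 4 nor that from compound 2 to compound 4 can be read as a step. The compounds shown leave open where any of the four actual values lies, and whether either change alters toxicity in this assay at all.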